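Working notes: replacing 4-fluorophenyl, cytotoxicity read-out

This account rests on a few compounds, and the source may have more. Where it says the series, first, only, none or still open, it means among the compounds named here.

- compound 1 `COc1ccc(-c2nc3cnccn3c2Nc2cc(OC)c(OC)c(OC)c2)cc1O` gives 38000 nM
- compound 2 `COc1cc(Nc2c(-c3ccc(F)cc3)nc3cnccn23)cc(OC)c1OC` gives 36000 nM

In a functional assay on HEK-293T cells (Homo sapiens) for cytotoxicity, read by MTT assay (on this read-out higher numbers stand for lower toxicity in this test and lower numbers for higher toxicity in this test), compound 2 gives 36000 nM and stands within the scatter of compound 1. Compound 3 `COc1cc(Nc2c(C3C=Nc4ccccc43)nc3cnccn23)cc(OC)c1OC` differs from compound 2 by one change a group of 9 heavy atoms (8 carbon, 1 nitrogen; one five-membered non-aromatic ring with 1 hetero atom, one six-membered aromatic ring of carbon only) in place of a group of 7 heavy atoms (6 carbon, 1 fluorine; one six-membered aromatic ring of carbon only), on an aromatic carbon at that position. Within the data shown here, the only measured step that bears on it is a 1.1-fold lower number from compound 1 to compound 2 (0.02 log units; within the scatter) and it also replaces the group on an aromatic carbon. One step is thin evidence, so the range stays wide. No shift beyond the scatter is expected in this assay and the expected step is a 1.2-fold lower number from compound 2 to compound 3 (0.08 log units; within the scatter) on this estimate. Compound 3 is estimated at 30000 nM with an expected range of 12000 nM to 75000 nM as the working figure.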

Compound 3, concentration lethal to 50% of the cells: 12000 nM
The estimate for compound 3 lay 2.5-fold (0.40 log units) above the measured number, within the range that was stated.
By their numbers in this assay, from the lowest: compound 3; then compounds 2 and 1 (each within the scatter of the next).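

In this assay this position is no longer silent: the group with the five-membered non-aromatic ring gives a 3.0-fold lower number from compound 2 to compound 3 (0.48 log units; beyond the scatter), and set against the 3-hydroxy-4-methoxyphenyl group it gives a 3.2-fold lower number from compound 1 to compound 3 (0.50 log units; beyond the scatter). The exchange between the two phenyl groups left the number within the scatter, so the first shift at this aromatic carbon toward higher toxicity in this test comes with the new ring group. Nothing measured speaks to the cause of this shift. Still open, as far as these compounds go, is how a simple amine or a carboxylic acid at this carbon would read. Also open, from the compounds shown here alone, is whether the shift would persist with the double bond outside aromatic rings saturated.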